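This account rests on a few compounds, and the source may have more. Where it says the series, first, only, none or still open, it means among the compounds named here.

Measured in a functional assay on HEK293 cells for antagonist activity at thromboxane A2 receptor (Homo sapiens), read by fluorescence and calcium flux; a lower number here means a stronger inhibitor, a higher number a weaker inhibitor:
compound 1 `Cc1ccccc1Oc1ccc(C#N)cc1S(=O)(=O)NC(=O)NC(C)(C)C` gives 1470 nM
compound 2 `CC(C)(C)NC(=O)NS(=O)(=O)c1cc(C#N)ccc1Oc1ccc(Cl)cc1` gives 5270 nM
compound 3 `Cc1ccccc1Nc1ccc(C#N)cc1S(=O)(=O)NC(=O)NC(C)C` gives 10100 nM

Compound 3 stands highest of the three numbers in this assay; its gap to compound 2 lies within the scatter, its gap to compound 1 beyond it. For the measured compounds named here, the only single-change step measured, a 3.6-fold higher number from compound 1 to compound 2 (0.55 log units; beyond the scatter), concerns the aryl on the oxygen and leaves the urea end untouched, so it gives no direct guidance on the change from compound 3 to compound 4 `Cc1ccccc1Nc1ccc(C#N)cc1S(=O)(=O)NC(=O)NC(C)(C)C`: methyl in place of hydrogen on a saturated chain carbon bound to an amide-type nitrogen and two saturated chain carbons. Going by the values given here, compounds 1 and 2 already carry the tert-butyl group, but they differ from compound 3 in the linker as well, so no measured pair isolates this change. For compound 4 a shift of about a 1.4-fold lower number from compound 3 to compound 4 (0.16 log units; within the scatter) is expected in this assay, not beyond the scatter. The estimate for compound 4 is 7000 nM, range 2500 nM to 20000 nM.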

Compound 4, half-maximal inhibitory concentration: 4780 nM
The estimate for compound 4 lay 1.5-fold (0.17 log units) above the measured number, within the range that was stated.
By their numbers in this assay, from the lowest: compound 1; then compounds 4, 2 and 3 (each within the scatter of the next, the first and the last beyond it).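

Tert-butyl in place of isopropyl gives a 2.1-fold lower number from compound 3 to compound 4 (0.32 log units; beyond the scatter) in this assay and is the first measured step at this position. With tert-butyl held, (2-methylphenyl)amino in place of 2-methylphenoxy gives a 3.3-fold higher number from compound 1 to compound 4 (0.51 log units; beyond the scatter) and costs potency, whereas (2-methylphenyl)amino in place of 4-chlorophenoxy gives a 1.1-fold lower number from compound 2 to compound 4 (0.04 log units; within the scatter) with no separation from compound 2. No supporting data bear on the reason for these steps.

As far as these compounds go, whether the isopropyl to tert-butyl step carries over to the 2-methylphenoxy series remains open. A cyclohexyl group or a longer chain at this position also remains untested among these compounds.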